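The source may report more compounds than this note shows. Statements on the series, on what has been measured and on what is new or still open speak of the compounds shown alone.

Measured compounds:
compound 1 `CCCCC(CC)C(=O)Nc1ccc2ccn(Cc3ccc(C(=O)NS(=O)(=O)c4ccc(F)cc4)cc3OC)c2c1`: 7.7
compound 2 `COc1cc(-c2nn[nH]n2)ccc1Cn1ncc2ccc(NC(=O)OC3CCCC3)cc21`: 7.7

In a functional assay (trachea) for antagonist activity, with Cavia porcellus as the target (on this read-out lower numbers stand for lower potency and higher numbers for higher potency (the scale is a negative logarithm)), compound 1 gives 7.7, and compound 2 gives 7.7; at the digits shown the two are level, within the usual scatter of the method. Compound 3 `CCCCC(CC)C(=O)Nc1ccc2ccn(Cc3ccc(C(=O)NS(=O)(=O)c4ccc([N+](=O)[O-])cc4)cc3OC)c2c1` differs from compound 1 by nitro in place of fluoro on an aromatic carbon, the exchange sitting on an aromatic carbon of a six-membered aromatic ring of carbon only. Going by the values given here, no step between measured compounds gauges this exchange, so nothing firm guides the direction. For compound 3 the expected step in this assay is a number 0.10 log units higher from compound 1 to compound 3 (within the scatter), likely nothing beyond the scatter. Compound 3 is therefore estimated at 7.8, within 7.2 to 8.4.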

Compound 3, negative logarithm of the antagonist equilibrium constant: 7.7
Compound 3: the middle estimate sits 0.10 log units above what was measured; the measured number falls inside the stated range.
By their numbers in this assay, from the lowest: compounds 1, 2 and 3 (each within the scatter of the next).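

In this assay, nitro in place of fluoro on the aromatic carbon para to a large group gives no change at the digits printed from compound 1 to compound 3 (within the scatter). Going by these compounds alone, the first measurement at this position thus shows that it accepts nitro as well as fluoro, although nitro brings more heavy atoms and two hydrogen-bond acceptors. Nothing available explains this tolerance. The compounds shown leave open whether an amine or a carboxylic acid on this carbon would also hold the value. They also leave open whether a longer chain there would do the same.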